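Methylating the amine of compound 2

A few compounds are considered here, and "the series" means these few. Any claim that something is new, unique, unknown or untested is made for them only; others in the source may bear on it.

Measured so far:
compound 1 `CC[C@H](NC)C(=O)N[C@@H]1C(=O)N2[C@@H](CC[C@@H]1CCN)CC[C@H]2C(=O)NC(c1ccccc1)c1ccccc1`: 31000 nM
compound 2 `CCNCC[C@H]1CC[C@H]2CC[C@@H](C(=O)NC(c3ccccc3)c3ccccc3)N2C(=O)[C@H]1NC(=O)[C@@H](N)CC`: 62800 nM

In a functional assay on HL-60 cells (Homo sapiens) for cytotoxicity, read by MTT assay, with a stated time of 96 h (on this read-out lower numbers stand for stronger inhibition and higher numbers for weaker inhibition), compound 2 holds the higher of the two numbers, at 62800 nM. Compound 1 gives 31000 nM. The gap between these two values lies beyond the scatter. Compound 3 `CCNCC[C@H]1CC[C@H]2CC[C@@H](C(=O)NC(c3ccccc3)c3ccccc3)N2C(=O)[C@H]1NC(=O)[C@H](CC)NC` arises from compound 2 by methyl in place of hydrogen on an amine nitrogen. For the measured compounds named here, no measured step isolates this change, so the expectation is weak and rests only on the lower number of compound 1 at 31000 nM. The expected change is a 1.7-fold lower number from compound 2 to compound 3 (0.22 log units; within the scatter), a modest shift towards lower numbers, near the scatter. For compound 3 the estimated value is 38000 nM, with an expected range of 14000 nM to 90000 nM.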

Compound 3, half-maximal inhibitory concentration: 76400 nM
Beside the measured number, compound 3's estimate is 2.0-fold (0.30 log units) below it; the range from low to high includes it.
By their numbers in this assay, from the lowest: compound 1; then compounds 2 and 3 (each within the scatter of the next).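

In this assay, methyl in place of hydrogen on the amine nitrogen of the 1-aminopropyl group gives a 1.2-fold higher number from compound 2 to compound 3 (0.09 log units; within the scatter), so at this nitrogen the methyl leaves the number within the scatter. Ethyl in place of hydrogen on the other amine nitrogen gives a 2.5-fold higher number from compound 1 to compound 3 (0.39 log units; beyond the scatter), the one step of these two beyond the scatter, and it is modest.

On these data alone, whether a longer chain such as propyl, or an acetyl group, on either amine nitrogen would move the number stays open. Nothing available accounts for either step.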